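Stereochemistry in cytosolic endo-beta-N-acetylglucosaminidase inhibition

A few compounds are considered here, and "the series" means these few. Any claim that something is new, unique, unknown or untested is made for them only; others in the source may bear on it.

Of the compounds shown here, three have been tested in an assay on isolated protein for inhibition of cytosolic endo-beta-N-acetylglucosaminidase (Homo sapiens), tested at 1000 uM; a higher number here means more inhibition at the concentration tested (going by the name of the read-out), a lower number less inhibition. Compound 1 `O=C(O)[C@@H]1NCC=C[C@H]1O` gives 14%, its mirror image compound 3 `O=C(O)[C@H]1NCC=C[C@@H]1O` gives 60%, and compound 2 `O=C(O)[C@H]1NC[C@@H](O)[C@@H](O)[C@@H]1O` gives 28%, the second highest of the three, above compound 1 and well below compound 3. The inversion of both stereocentres produced a number 46 percentage points higher from compound 1 to compound 3 (beyond the scatter), a large step explained only by the fact that compounds 1 and 3 differ only in the configuration as drawn. Compound 4 `O=C(O)[C@@H]1NC[C@@H](O)[C@H](O)[C@@H]1O` differs from compound 2 in this way: the two compounds have the same atoms and bonds and differ only in configuration as drawn: 2 of 4 stereo elements differ; a stereocentre at a saturated ring carbon is drawn S in compound 2 and R in compound 4; a stereocentre at a saturated ring carbon is drawn R in compound 2 and S in compound 4. Among the measured compounds shown here, the one measured change of configuration alone was large, so a step beyond the scatter is expected for a number 8 percentage points lower from compound 2 to compound 4 (within the scatter), here estimated as a decrease. Compound 4 is therefore expected to give 20%, within 5% to 50%.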

Compound 4, a percentage reported as inhibition, at one concentration (the size of the read-out at that concentration, not a potency): 0.8%
Compound 4: the middle estimate sits 19.2 percentage points above what was measured; the whole stated range lies above it.
By their numbers in this assay, from the lowest: compound 4; then compound 1; then compound 2; then compound 3.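

In this assay the new pair gives a number 27.2 percentage points lower from compound 2 to compound 4 (beyond the scatter), so inverting only 2 of 4 stereo elements is enough to move the result, and a full mirror-image change is not required. The direction is also opposite to that of the earlier step, a number 46 percentage points higher from compound 1 to compound 3 (beyond the scatter), so a change of configuration has no single direction across these two pairs. The new step has one possible source: the fact that compounds 2 and 4 differ only in the configuration as drawn

The compounds shown leave open which of the two inverted stereocentres accounts for the drop. They also leave open how a methyl ester or an amide in place of the carboxylic acid would fare.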